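Chromene esters and acids: cell inhibition working notes

The source may hold more compounds than are shown below. What is called first, only, known or untested is meant among the compounds shown, and "the series" means these compounds.

Measured so far:
compound 1, `CCOC(=O)C1=Cc2ccccc2OC1(OCc1cc(-c2ccc(Br)cc2)no1)C(F)(F)F`: > 150000 nM, a limit of the assay.
compound 2, `O=C(O)C1=Cc2ccccc2OC1(OCc1cc(-c2ccc(F)cc2)no1)C(F)(F)F`: > 150000 nM, a limit of the assay.

Both values come from a functional assay on A549 cells (Homo sapiens) for inhibition, read by MTT assay, with a stated time of 24 h; a lower number here means a stronger inhibitor, a higher number a weaker inhibitor. Compound 2 stands at the limit of this assay; (the limit of > 150000 nM in this assay, at which 2 of the 2 values shown sit), so no number separates compound 2 from compound 1. Compound 3, `CCOC(=O)C1=Cc2ccccc2OC1(OCc1cc(-c2ccc(F)cc2)no1)C(F)(F)F`, differs from compound 2 in one place: ethyl in place of hydrogen on an oxygen next to a carbonyl group. Going by the values given here, no step between measured compounds exists to calibrate this change; compound 1 carries the same ethyl group and also sits at the limit. In this assay the expected step is none beyond the scatter: a step that the limit leaves unreadable from compound 2 to compound 3. Compound 3 is therefore expected to return only a limit again, with an estimated value of 200000 nM and a range from 80000 nM to 600000 nM.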

Compound 3, half-maximal inhibitory concentration: 35500 nM
Compound 3: the middle estimate sits 5.6-fold (0.75 log units) above what was measured; measured number outside the range, below it.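

In this assay only the ethyl ester carrying fluoro gives a number rather than a limit, and ethyl in place of hydrogen on an oxygen next to a carbonyl group brings an at least 4.2-fold lower number from compound 2 to compound 3 (0.62 log units; beyond the scatter) for this change at this position. With the ethyl ester held constant, fluoro in place of bromo on an aromatic carbon brings an at least 4.2-fold lower number from compound 1 to compound 3 (0.62 log units; beyond the scatter) so the halogen also shifts the read-out. Both steps are minimum sizes, and their full size cannot be read, since the starting compounds sit at a limit: the limit of > 150000 nM in this assay, at which 2 of the 3 values shown sit.

The compounds shown leave open whether a longer chain such as propyl, or an amide in place of the ester, moves the number further. They also leave open what chloro would give on the same aromatic carbon.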